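Ethyl Gives Way to a Methoxyethoxy Chain

The source may hold more compounds than are shown below. What is called first, only, known or untested is meant among the compounds shown, and "the series" means these compounds.

Compound 1 `CC1=C(N2CC2)C(=O)C(C(C)COC(N)=O)=C(N2CC2)C1=O` and compound 2 `CCC(COC(N)=O)C1=C(N2CC2)C(=O)C(C)=C(N2CC2)C1=O` share one core and differ in a single group. In a functional assay on L1210 cells (Mus musculus), with a stated time of 1 days (on this read-out lower numbers stand for lower potency and higher numbers for higher potency (the scale is a negative logarithm)), compound 1 gives 5.31 and compound 2 gives 5.2. Compound 2 stands alongside compound 1 rather than apart from it: the step of a number 0.11 log units lower from compound 1 to compound 2 (within the scatter) is within the scatter, so the two numbers cannot be told apart.

Compound 3 `COCCOC(COC(N)=O)C1=C(N2CC2)C(=O)C(C)=C(N2CC2)C1=O` carries the change (2-methoxyethoxy in place of ethyl on a saturated chain carbon bound to a double-bonded ring carbon and a saturated chain carbon). For the measured compounds named here, no measured step covers an exchange of this kind; the only step measured so far concerns a different change and stayed within the scatter. There is therefore no basis for expecting a step beyond the scatter in this assay in either direction. Compound 3 is expected to give about 5.2, with a range from 4.7 to 5.7. This estimate means a step of no change at the digits printed from compound 2 to compound 3 (within the scatter) that is expected to lie within the scatter.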

Compound 3, logarithm of the reciprocal of the active concentration, log(1/C): 4.96
Compound 3: middle estimate off by 0.24 log units, on the high side, within the range that was stated.
By their numbers in this assay, from the lowest: compounds 3, 2 and 1 (each within the scatter of the next, the first and the last beyond it).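

In this assay, putting 2-methoxyethoxy in place of ethyl on this saturated chain carbon gives a number 0.24 log units lower from compound 2 to compound 3 (within the scatter), so the longer, oxygen-bearing chain cannot be told apart from ethyl here. For the compounds shown here, measured against methyl on the same carbon, the same chain gives a number 0.35 log units lower from compound 1 to compound 3 (beyond the scatter) and is the first exchange in this set to pass the scatter, though only modestly, so this position still keeps much of its activity with the larger group in place. Nothing available here accounts for either step.

On these data alone, what remains open is whether the step away from methyl follows chain length or the oxygens of the new chain, which a butyl chain made only of carbon would help to separate. As far as these compounds go, how an amine or a carboxylic acid would read on this carbon also remains unknown.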